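A few compounds are considered here, and "the series" means these few. Any claim that something is new, unique, unknown or untested is made for them only; others in the source may bear on it.

In an ADME assay on RAW264.7 cells (Mus musculus) for cytotoxicity, read by MTT assay, with a stated time of 24 h (on this read-out higher numbers stand for lower toxicity in this test and lower numbers for higher toxicity in this test), compound 1 `CC/C=C\C[C@H]1C(=O)C=C[C@H]1CC(=O)OCc1ccccc1` gives 31 uM, compound 2 `CC/C=C\C[C@H]1C(=O)C=C[C@H]1CC(=O)OC(C)CC` gives 53 uM, and compound 3 `CC/C=C\C[C@H]1C(=O)C=C[C@H]1CC(=O)OC(C)COC` gives 161 uM, the highest number of the three. Compound 4 `CC/C=C\C[C@H]1C(=O)C=C[C@H]1CC(=O)OC(C)c1ccccc1` has phenyl in place of methoxymethyl on a saturated chain carbon bound to an oxygen next to a carbonyl group and a saturated chain carbon. For the measured compounds named here, two measured steps bear most closely on this change: a 5.2-fold higher number from compound 1 to compound 3 (0.72 log units; beyond the scatter) and a 3.0-fold higher number from compound 2 to compound 3 (0.48 log units; beyond the scatter). Both reached compound 3 by introducing the methoxy-bearing group, and compound 4 lacks it. Meanwhile, a 1.7-fold higher number from compound 1 to compound 2 (0.23 log units; within the scatter) separates benzyl from sec-butyl by no more than the scatter. A modest step to a lower number is therefore expected, a 4.9-fold lower number from compound 3 to compound 4 (0.69 log units; beyond the scatter). For compound 4 the estimated value is 33 uM, with an expected range from 15 uM to 70 uM.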

Compound 4, half-maximal toxic concentration: 31 uM
Compound 4: middle estimate off by 1.1-fold (0.03 log units), on the high side, within the range that was stated.
By their numbers in this assay, from the lowest: compounds 1, 4 and 2 (each within the scatter of the next); then compound 3.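

With the methyl on this saturated chain carbon kept, phenyl in place of methoxymethyl gives a 5.2-fold lower number from compound 3 to compound 4 (0.72 log units; beyond the scatter), so compound 3 alone stands apart among the four. Adding that methyl to the benzyl group gives no change at the digits printed from compound 1 to compound 4 (within the scatter), and phenyl in place of ethyl gives a 1.7-fold lower number from compound 2 to compound 4 (0.23 log units; within the scatter), so compound 1, compound 2 and compound 4 cannot be told apart here. Nothing available explains the separation of compound 3 from the others. Going by these compounds, it remains open whether a hydroxyl, an amine or a longer ether chain in place of methoxymethyl at this carbon would give a number as high as that of compound 3.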